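The compounds below may be only part of what the source reports. "The series", "measured", "known", "first", "only" and "open" are said of these compounds alone.

Measured in a functional assay on KB cells (nasopharynx, Homo sapiens) for antiproliferative activity; on this read-out higher numbers stand for weaker inhibition and lower numbers for stronger inhibition:
compound 1 `N#Cc1ccc(S(=O)(=O)Nc2cccc3cc[nH]c23)cc1`: 8.5 ug/mL
compound 2 `CS(=O)(=O)Nc1ccc(S(=O)(=O)Nc2cccc3c(C#N)c[nH]c23)cc1`: 15 ug/mL
compound 3 `N#Cc1ccc(S(=O)(=O)Nc2cccc3c(Cl)c[nH]c23)cc1`: 11 ug/mL

Compound 3 lies within the scatter of both other compounds, so its value sets it apart from neither. Compound 4 `CS(=O)(=O)Nc1ccc(S(=O)(=O)Nc2cccc3c(Cl)c[nH]c23)cc1` differs from compound 3 by methanesulfonamido in place of cyano on an aromatic carbon, para to a large group: methanesulfonamido in place of cyano on an aromatic carbon. Within the data shown here, the only measured step, a 1.3-fold higher number from compound 1 to compound 3 (0.11 log units; within the scatter), is chloro in place of hydrogen, a different change, and it stays within the scatter. Among the measured compounds shown here, no measured step covers this exchange itself. Compound 2, which also carries methanesulfonamido, gives 15 ug/mL, so no step beyond the scatter is expected in this assay. The expected value for compound 4 is 12 ug/mL, with an estimated range from 5 ug/mL to 28 ug/mL.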

Compound 4, half-maximal inhibitory concentration: 12 ug/mL
Estimate against measurement, compound 4: no gap at the digits printed; low and high end bracket the measured number.
By their numbers in this assay, from the lowest: compounds 1, 3, 4 and 2 (each within the scatter of the next).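

In this assay, the exchange on the aromatic carbon para to a large group now has a direct reading, a 1.1-fold higher number from compound 3 to compound 4 (0.04 log units; within the scatter), so the larger methanesulfonamido group leaves the number where cyano had it. With methanesulfonamido held in place, chloro in place of cyano on the other aromatic carbon also moves little, a 1.3-fold lower number from compound 2 to compound 4 (0.10 log units; within the scatter). Nothing measured here accounts for either result. On these data alone, whether an amine or a carboxylic acid at the para carbon would also stay within the scatter remains open.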